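The source may hold more compounds than are shown below. What is called first, only, known or untested is meant among the compounds shown, and "the series" means these compounds.

Two compounds in this series carry measured numbers. Compound 1 `CN(Cc1cccc(B(O)O)c1)c1ncc(C(=O)Nc2ccc(F)cc2)cn1` was tested in a functional assay on RBL cells for antagonist activity at C-X-C chemokine receptor type 1 (Homo sapiens), read by fluorescence and calcium flux, with a stated time of 30 min (on this read-out lower numbers stand for stronger inhibition and higher numbers for weaker inhibition), and compound 1 gives 2500 nM. Compound 2 `O=C(Nc1ccc(F)cc1)c1ccc(N(Cc2ccccc2)Cc2ccc(B(O)O)cn2)nc1` in this assay gives 326 nM. Of these two numbers compound 2 holds the lower one, and its gap to compound 1 lies beyond the usual scatter of repeated measurements, so compound 2 is the stronger inhibitor of the pair. The still unmeasured compound 3 `O=C(Nc1ccc(F)cc1)c1ccc(N(Cc2ccc(B(O)O)cn2)Cc2ccco2)nc1` arises from compound 2 by a single change: furan-2-yl in place of phenyl on a saturated chain carbon bound to a nitrogen on an aromatic ring. For the measured compounds named here, no two measured compounds differ at this place alone, so the size of such a step cannot be read off from the measured values, and compounds 1 and 2 differ in several places at once, so their gap is no guide either. A step of modest size toward a somewhat higher number is expected, and the estimated step in this assay is a 1.5-fold higher number from compound 2 to compound 3 (0.19 log units; within the scatter). Compound 3 is thus expected to give about 500 nM in this assay, with a range from 150 nM to 1500 nM.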

Compound 3, half-maximal inhibitory concentration: 3.3 nM
The estimate for compound 3 lay 150-fold (2.18 log units) above the measured number, outside the stated range (below it).
By their numbers in this assay, from the lowest: compound 3; then compound 2; then compound 1.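

In this assay, for the compounds shown here, furan-2-yl in place of phenyl on a saturated chain carbon bound to a nitrogen on an aromatic ring gives a 99-fold lower number from compound 2 to compound 3 (1.99 log units; beyond the scatter), a large step beyond the scatter, and it shows that the number in this assay depends strongly on the ring carried at this place, which no earlier pair could show. The change is modest when counted: a six-membered aromatic ring of six carbon atoms leaves, a five-membered aromatic ring of four carbon atoms and one oxygen enters, and the count of hydrogen-bond acceptors goes from 0 to 1. Nothing given here accounts for why so modest a change brings so large a step.

The compounds shown leave open whether this step belongs to furan-2-yl alone or would also come with another ring at this place, such as furan-3-yl, thiophen-2-yl or pyridin-2-yl. They also leave open whether a non-aromatic group on the same chain carbon, such as cyclopropyl or a tetrahydrofuran-2-yl ring, would keep any of this gain.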